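From isopropoxy to butoxy on a shared core

The source may report more compounds than this note shows. Statements on the series, on what has been measured and on what is new or still open speak of the compounds shown alone.

Compound 1 (`CCOC(=O)c1ccc(-c2ccc(N(CC)CC)nn2)cc1`): 1000 nM
Compound 2 (`CCOC(=O)c1ccc(-c2ccc(OCC)nn2)cc1`): > 25000 nM
Compound 3 (`CCOC(=O)c1ccc(-c2ccc(OC(C)C)nn2)cc1`): > 25000 nM

In a functional assay on PC-3 cells (Homo sapiens) for antiproliferative activity, with a stated time of 48 h (on this read-out lower numbers stand for stronger inhibition and higher numbers for weaker inhibition), compound 1 gives 1000 nM and is the only one of the three with a true number. Compound 2 reads > 25000 nM and this is a limit of the assay, not a number. Compound 3 reads > 25000 nM and this too is only a limit. The data therefore rest largely on the limit of > 25000 nM in this assay, at which 2 of the 3 values shown sit, and on one measured value.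

Two measured steps start from compound 1. Ethoxy gives an at least 25-fold higher number from compound 1 to compound 2 (1.39 log units; beyond the scatter) and isopropoxy gives an at least 25-fold higher number from compound 1 to compound 3 (1.39 log units; beyond the scatter) and both are large and beyond the scatter. Between the two alkoxy compounds there is only a step that the two limits leave unreadable from compound 2 to compound 3 and so the effect of changing the chain on oxygen cannot be read.

Compound 4 (`CCCCOc1ccc(-c2ccc(C(=O)OCC)cc2)nn1`) differs from compound 3 as follows: butyl in place of isopropyl on an oxygen on an aromatic ring that is, butyl in place of isopropyl on an oxygen on an aromatic ring. It stays an alkoxy compound, so the closest guides are compound 2 and compound 3 rather than compound 1, and no large step is expected. Compound 4 is thus expected to show a number no higher from compound 3 to compound 4 (the limit leaves the size open) with nothing readable beyond the scatter, and a further limit is the likeliest report. The estimate for compound 4 is 25000 nM with an expected range of 8000 nM to 60000 nM in this assay for now.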

Compound 4, half-maximal inhibitory concentration: > 25000 nM
Compound 4 ended at the assay's limit; the forecaster's own chance of this, stated with the estimate: 70%; the middle value lies on the limit itself.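

Butoxy in place of diethylamino gives an at least 25-fold higher number from compound 1 to compound 4 (1.39 log units; beyond the scatter), so a straight butyl chain on the oxygen shows the same large step from compound 1 that ethoxy and isopropoxy showed. In this assay, the steps among compound 2, compound 3 and compound 4 cannot be read, as each of them joins two limits, and lengthening the chain to butyl therefore brings no measurable number into the alkoxy series. Among the compounds shown, the ethoxy, isopropoxy and butoxy groups all end at the same limit and only compound 1, with diethylamino, gives a true number, so the comparison of this position rests mainly on one boundary: the limit of > 25000 nM in this assay, at which 3 of the 4 values shown sit.

As far as these compounds go, how far the three alkoxy compounds lie past that limit, and whether they differ from one another at all, remains open. From the compounds shown here alone, it is also open whether the true number of compound 1 belongs to diethylamino alone or extends to other amines on that aromatic carbon, such as dimethylamino or dipropylamino, and whether it would survive a carboxylic acid in place of the ethyl ester.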